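Chloro on the Core: Expecting Another Assay Limit

The compounds below may be only part of what the source reports. "The series", "measured", "known", "first", "only" and "open" are said of these compounds alone.

Measured so far:
Compound 1, `C#CCn1cc(C(=O)NC(CC(=O)Nc2ccccc2)c2ccccc2)c(=O)c2cccnc21`, gives > 10000 nM in a functional assay on K562 cells (Homo sapiens) for cytotoxicity, read by MTT assay, with a stated time of 72 h; on this read-out higher numbers stand for weaker inhibition and lower numbers for stronger inhibition.
Compound 2, `C#CCn1cc(C(=O)NC(CC(=O)Nc2ccccn2)c2ccccc2)c(=O)c2cc(F)c(Cl)nc21`, gives > 10000 nM in this assay.

The value for compound 1 is a limit of the assay, not a number. The value for compound 2 is a limit as well. Going by the values given here, both results sit at the limit of > 10000 nM in this assay, at which 2 of the 2 values shown sit, so no step between measured compounds can be counted, and compound 1 stands simply at the limit, with nothing in the measured data to place it above or below compound 2.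

Compound 3, `C#CCn1cc(C(=O)NC(CC(=O)Nc2ccccc2)c2ccccc2)c(=O)c2ccc(Cl)nc21`, has not yet been measured. It differs from compound 1 by chloro in place of hydrogen on an aromatic carbon. Among the compounds with values here, no measured step exists for this change, and the two measured values show only that both compounds failed to reach a number.

The expectation for compound 3 is therefore that it also reaches only the limit, meaning no change beyond the scatter in this assay. The expected step that the limit leaves unreadable from compound 1 to compound 3 is close to none. Compound 3 is estimated at 20000 nM, with a range from 5000 nM to 80000 nM.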

Compound 3, half-maximal inhibitory concentration: 7700 nM
Beside the measured number, compound 3's estimate is 2.6-fold (0.41 log units) above it, within the range that was stated.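

In this assay, compound 3 is the first compound shown to give an actual number rather than a limit, so chloro in place of hydrogen, on the aromatic carbon next to the ring nitrogen, is the first change here that brings a result within reach of the assay. The change reads as an at least 1.2-fold lower number from compound 1 to compound 3 (0.11 log units; that floor lies within the scatter), which is only a floor on its size: the true step may be larger, but the data guarantee nothing beyond the usual scatter. The step can be given only as a floor because compound 1 rests at a limit and not at a number: the limit of > 10000 nM in this assay, at which 2 of the 3 values shown sit.

As far as these compounds go, it remains open whether chlorine itself matters or whether another group on the same carbon, such as an amine or a methoxy group, would give a similar number or a different one. Compound 2 also carries chloro, but it differs from compound 3 in more than one place, so the compounds shown cannot tell whether this change would have the same effect on a different amide or a differently substituted core.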